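The compounds below may be only part of what the source reports. "The series", "measured", "known", "first", "only" and "open" are said of these compounds alone.

Measured so far in an ADME assay on BaF3 cells (Mus musculus) for cytotoxicity; on this read-out higher numbers stand for an effect only at larger amounts of compound and lower numbers for an effect already at smaller amounts:
- compound 1 `NS(=O)(=O)c1cccc(-c2cc(Nc3ccc(OC(F)(F)F)cc3)ncn2)c1`: > 10000 nM
- compound 2 `NC(=O)c1cccc(Oc2cc(Nc3ccc(OC(F)(F)F)cc3)ncn2)c1`: > 10000 nM
- compound 3 `CCn1cc2c(Nc3ccc(OC(F)(F)F)cc3)ncnc2n1`: > 10000 nM

Compound 1 gives > 10000 nM in this assay, and this is a limit of the assay rather than a measured number. Compound 2 likewise reaches only a limit, > 10000 nM. Compound 3 also stops at a limit, > 10000 nM. All three values therefore sit at the limit of > 10000 nM in this assay, at which 3 of the 3 values shown sit, so compound 1 stands at the same limit as the other two, and the numbers shown do not separate any of them. Within the data shown here, no step between measured compounds can be counted from such limits.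

Compound 4 `CS(=O)(=O)c1cccc(-c2cc(Nc3ccc(OC(F)(F)F)cc3)ncn2)c1` is the next compound to be measured in this assay. It differs from compound 1 in one place: methyl in place of amino on a sulfonyl sulfur. The change is small in count and keeps the rest of the structure of compound 1 unchanged.

Because every measured compound sits at the limit of > 10000 nM in this assay, at which 3 of the 3 values shown sit, the step that the limit leaves unreadable from compound 1 to compound 4 is expected to be none beyond the scatter, with compound 4 most likely reporting a limit too. Compound 4 is therefore estimated at 15000 nM in this assay, with a range from 5000 nM to 50000 nM.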

Compound 4, half-maximal effective concentration: > 10000 nM
Compound 4 ended at the assay's limit; the forecaster's own chance of this, stated with the estimate: 80%; the middle value is on the limit's open side.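

Compound 4 also stops at a limit of the assay, > 10000 nM in this assay. No size can be read for the change from compound 1 to compound 4, because both compounds sit at the same limit: the limit of > 10000 nM in this assay, at which 4 of the 4 values shown sit.

The compounds shown leave open whether methylsulfonyl in place of sulfamoyl shifts the cytotoxicity at all, and at what amount any of the four compounds would show an effect.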